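A few compounds are considered here, and "the series" means these few. Any claim that something is new, unique, unknown or untested is made for them only; others in the source may bear on it.

- Compound 1 `CCCCOC(=O)CNC(=O)[C@H](CSc1ccc([N+](=O)[O-])cc1[N+](=O)[O-])NC(=O)CC[C@H](NC(=O)OC)C(=O)OCCCC`: > 300 uM, a limit of the assay
- Compound 2 `CCCCOC(=O)CNC(=O)[C@H](CSc1ccc([N+](=O)[O-])cc1[N+](=O)[O-])NC(=O)CC[C@H](NC(C)=O)C(=O)OCCCC`: > 300 uM, a limit of the assay
- Compound 3 `CCCCOC(=O)CNC(=O)[C@H](CSc1ccc([N+](=O)[O-])cc1[N+](=O)[O-])NC(=O)CC[C@H](NC(=O)CC(C)(C)C)C(=O)OCCCC`: 250 uM

For the measured compounds named here, in a toxicity assay on KB cells (Homo sapiens) for cytotoxicity, read by fluorescence, with a stated time of 3 days (on this read-out higher numbers stand for an effect only at larger amounts of compound and lower numbers for an effect already at smaller amounts), compound 3 gives 250 uM, the only true number so far. The other two results are not numbers: the limit of > 300 uM in this assay, at which 2 of the 3 values shown sit. Compound 4 `CCCCOC(=O)CNC(=O)[C@H](CSc1ccc([N+](=O)[O-])cc1[N+](=O)[O-])NC(=O)CC[C@H](Nc1ccc([N+](=O)[O-])cc1[N+](=O)[O-])C(=O)OCCCC` differs from compound 3 at one place, an amine nitrogen: 2,4-dinitrophenyl in place of neopentylcarbonyl on an amine nitrogen.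

Two measured steps change the group on that nitrogen: an at least 1.2-fold lower number from compound 1 to compound 3 (0.07 log units; that floor lies within the scatter) and an at least 1.2-fold lower number from compound 2 to compound 3 (0.07 log units; that floor lies within the scatter). Both are floors within the scatter. The third, a step that the two limits leave unreadable from compound 1 to compound 2, gives no size. On these steps, no change beyond the scatter is expected, and no direction can be favoured. The expected size is a 1.3-fold lower number from compound 3 to compound 4 (0.10 log units; within the scatter). The estimate for compound 4 is 200 uM, with an expected range from 70 uM to 400 uM.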

Compound 4, concentration for half-maximal effect: > 300 uM
Compound 4 gave a limit, no number (the forecaster's own chance of this, stated with the estimate: 40%); middle value at least 1.5-fold (0.17 log units) away from the limit.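

In this assay, 2,4-dinitrophenyl in place of neopentylcarbonyl on an amine nitrogen gives an at least 1.2-fold higher number from compound 3 to compound 4 (0.07 log units; that floor lies within the scatter). The steps to compound 4 from compound 1 and from compound 2 cannot be read. So an aromatic ring on this nitrogen, like the open-chain groups before it, yields no step shown to lie beyond the scatter, and the series stays mostly at one limit: the limit of > 300 uM in this assay, at which 3 of the 4 values shown sit.

From the compounds shown here alone, whether a free amine or a benzoyl group on this nitrogen would give a step beyond the scatter remains open. Also open, going by these compounds, is whether such a group would give a true number at all.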